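The source may report more compounds than this note shows. Statements on the series, on what has been measured and on what is new or still open speak of the compounds shown alone.

Of the compounds shown here, two built on one shared core have been measured in a functional assay on PC-3 cells (Homo sapiens) for antiproliferative activity, read by MTT assay, with a stated time of 48 h; on this read-out higher numbers stand for weaker inhibition and lower numbers for stronger inhibition. Compound 1 `COc1cc(/C=C/C(C)=O)ccc1OCc1cn(-c2ccccc2CO)nn1` gives 50300 nM. Compound 2 `COc1cc(/C=C/C(C)=O)ccc1OCc1cn(-c2ccccc2Cl)nn1` gives 48000 nM in this assay. Within the data shown here, the single step that joins them, chloro in place of hydroxymethyl on an aromatic carbon, is a 1.0-fold lower number from compound 1 to compound 2 (0.02 log units; within the scatter). Compound 2 thus stands at the lower of the two numbers, yet that step shows the gap to compound 1 lies within the scatter, so the two cannot be told apart.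

Compound 3 `COc1cc(/C=C/C(C)=O)ccc1OCc1cn(-c2ccccc2O)nn1` has not yet been measured. It differs from compound 2 in one place: hydroxy in place of chloro on an aromatic carbon. Among the measured compounds shown here, the only measured step bears on this change, since it too swaps the group on that same aromatic carbon, and it stayed within the scatter. For the measured compounds named here, with one such comparison as the sole guide, the expected step from compound 2 to compound 3 is a 1.0-fold higher number from compound 2 to compound 3 (0.02 log units; within the scatter), that is, no shift beyond the scatter in this assay. Compound 3 is therefore estimated at about 50000 nM in this assay, with a range from 20000 nM to 125000 nM.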

Compound 3, half-maximal inhibitory concentration: 59200 nM
Estimate against measurement, compound 3: 1.2-fold (0.07 log units) below; low and high end bracket the measured number.
By their numbers in this assay, from the lowest: compounds 2, 1 and 3 (each within the scatter of the next).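

The aromatic carbon ortho to a large group has now carried three different groups, and in this assay every swap between them stays within the scatter: hydroxy in place of chloro gives a 1.2-fold higher number from compound 2 to compound 3 (0.09 log units; within the scatter) and hydroxy in place of hydroxymethyl gives a 1.2-fold higher number from compound 1 to compound 3 (0.07 log units; within the scatter). This adds something the first pair could not show, as hydroxy carries a hydrogen-bond donor and a hydrogen-bond acceptor while chloro carries neither, yet that difference in the counts goes with no shift beyond the scatter, so these three groups cannot be ranked at this position. No further measurement is at hand that could explain why the numbers stay so close.

On these data alone, whether an amine, a carboxylic acid or a longer chain on this same carbon would move the number beyond the scatter remains open, as all three groups seen so far are single substituents with no ring and no net charge. Also open, as far as these compounds go, is whether chloro or hydroxy would give a similarly flat result at another carbon of the same six-membered aromatic ring.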